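The compounds below may be only part of what the source reports. "The series", "measured", "known", "first", "only" and "open" are said of these compounds alone.

Values in a functional assay on MCF7 cells (Homo sapiens) for cytotoxicity, read by CellTiter-Glo, with a stated time of 5 days; on this read-out higher numbers stand for weaker inhibition and lower numbers for stronger inhibition:
compound 1 `CC/C(=C(/c1ccc(/C=C/C(=O)O)cc1)c1ccc2[nH]ncc2n1)c1ccccc1` — 33 nM
compound 2 `CC/C(=C(/c1ccc(/C=C/C(=O)O)cc1)c1ccc2[nH]ncc2c1C)c1ccccc1` — 50 nM
compound 3 `CC/C(=C(/c1ccc(/C=C/C(=O)O)cc1)c1cc(C)c2[nH]ncc2c1)c1ccccc1` — 59 nM

Compound 3 has the highest of the three numbers, but its separation from the others is slight: a 1.2-fold higher number from compound 2 to compound 3 (0.07 log units; within the scatter) and a 1.8-fold higher number from compound 1 to compound 3 (0.25 log units; within the scatter) are both within the scatter, so the three compounds stand together and no order among them is claimed.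

Compound 4 `CC/C(=C(/c1ccc(/C=C/C(=O)O)cc1)c1cc2cn[nH]c2cc1F)c1ccccc1` is not yet measured. It differs from compound 3 in one place: 6-fluoro-1H-indazol-5-yl in place of 7-methyl-1H-indazol-5-yl on a double-bonded chain carbon bound to an aromatic carbon and a double-bonded chain carbon. The shared core is untouched, and the count of one hydrogen-bond donor and one hydrogen-bond acceptor in the group is unchanged; a methyl leaves and a fluorine enters.

The step that bears most directly on this change is a 1.2-fold higher number from compound 2 to compound 3 (0.07 log units; within the scatter), a rearrangement of a methyl within the same kind of group, which stayed within the scatter. The larger swaps of the whole group, a 1.5-fold higher number from compound 1 to compound 2 (0.18 log units; within the scatter) and a 1.8-fold higher number from compound 1 to compound 3 (0.25 log units; within the scatter), also stayed within the scatter. Among the measured compounds shown here, no compound carrying a fluorine has been measured, so the fluorine itself is an open point. On these steps, the expected move is a 1.3-fold lower number from compound 3 to compound 4 (0.12 log units; within the scatter), nothing beyond the scatter. The estimate for compound 4 in this assay is 45 nM, expected to lie between 20 nM and 110 nM.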

Compound 4, half-maximal inhibitory concentration: 47 nM
Estimate against measurement, compound 4: 1.0-fold (0.02 log units) below; the measured number falls inside the stated range.
By their numbers in this assay, from the lowest: compounds 1, 4, 2 and 3 (each within the scatter of the next).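

In this assay, the 6-fluoro-1H-indazol-5-yl group brings the first fluorine to this double-bonded chain carbon, and it reads level with both methyl groups: 7-methyl-1H-indazol-5-yl gives way to it with a 1.3-fold lower number from compound 3 to compound 4 (0.10 log units; within the scatter) and 4-methyl-1H-indazol-5-yl with a 1.1-fold lower number from compound 2 to compound 4 (0.03 log units; within the scatter) as the two steps. Set against the group carrying a ring nitrogen in its six-membered ring, the same fluorine group gives a 1.4-fold higher number from compound 1 to compound 4 (0.15 log units; within the scatter) in this comparison, so all four groups at this place now stand together, and exchanging a methyl for a fluorine has produced no step beyond the scatter. No measurement on hand accounts for this flatness.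

From the compounds shown here alone, what the plain 1H-indazol-5-yl group, with only hydrogen in place of the methyl or the fluorine, would read in this assay remains open, and that value would give each of these groups a common reference. Among the compounds shown here, also open is whether a larger or differently charged substituent on the same group, such as a trifluoromethyl or an amine, would stay with these four compounds or produce the first step beyond the scatter at this place.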